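Chalcone-type series: pyridyl to bromothiophenyl on the carbonyl

The compounds below may be only part of what the source reports. "The series", "measured", "known", "first", "only" and "open" are said of these compounds alone.

Among the compounds with values here, compound 3 `COc1ccc(-c2cc3ccccc3nc2/C=C/C(=O)c2ccccn2)cc1` gives 4140 nM in a functional assay on H184B5F5/M10 cells (Homo sapiens) for antiproliferative activity, read by XTT assay, with a stated time of 72 h (a higher number here means a weaker inhibitor, a lower number a stronger inhibitor), the lowest of the three numbers so far. Compound 1 `COc1ccc(-c2cc3ccccc3nc2/C=C/C(=O)c2ccccc2)cc1` gives 8560 nM and compound 2 `COc1ccc(-c2cc3ccccc3nc2/C=C/C(=O)c2ccc(N)cc2)cc1` gives 9290 nM; the step of a 1.1-fold higher number from compound 1 to compound 2 (0.04 log units; within the scatter) stays within the scatter, while a 2.1-fold lower number from compound 1 to compound 3 (0.32 log units; beyond the scatter) and a 2.2-fold lower number from compound 2 to compound 3 (0.35 log units; beyond the scatter) are modest but beyond it.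

Compound 4 `COc1ccc(-c2cc3ccccc3nc2/C=C/C(=O)c2ccc(Br)s2)cc1` carries the change (5-bromothiophen-2-yl in place of pyridin-2-yl on a carbonyl carbon). Within the data shown here, no measured step covers this exchange. Among the measured compounds shown here, the only steps that bear on it are those replacing the aryl on the carbonyl carbon, a 2.1-fold lower number from compound 1 to compound 3 (0.32 log units; beyond the scatter) and a 2.2-fold lower number from compound 2 to compound 3 (0.35 log units; beyond the scatter), both modest, and both gained by moving to pyridin-2-yl; compound 4 gives that group up. The expectation is therefore a modest rise in this assay, of roughly the size seen when pyridin-2-yl is absent, i.e. back towards the range of compound 1 and compound 2, with wide uncertainty because the five-membered ring is new to the set.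

Compound 4 is expected at 6500 nM, range 2500 nM to 15000 nM, an expected step of a 1.6-fold higher number from compound 3 to compound 4 (0.20 log units; within the scatter).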

Compound 4, half-maximal inhibitory concentration: 9380 nM
Compound 4: the middle estimate sits 1.4-fold (0.16 log units) below what was measured; low and high end bracket the measured number.
By their numbers in this assay, from the lowest: compound 3; then compounds 1, 2 and 4 (each within the scatter of the next).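

In this assay, 5-bromothiophen-2-yl in place of pyridin-2-yl on the carbonyl carbon gives a modest loss (a 2.3-fold higher number from compound 3 to compound 4 (0.36 log units; beyond the scatter)), so this position responds to the exchange of one heteroaryl group for another, not only to the exchange of phenyl or 4-aminophenyl for pyridin-2-yl. The bromothiophene ketone shows no separation from the 4-aminophenyl ketone (a 1.0-fold higher number from compound 2 to compound 4 (0.00 log units; within the scatter)) or the phenyl ketone (a 1.1-fold higher number from compound 1 to compound 4 (0.04 log units; within the scatter)), which leaves pyridin-2-yl as the only one of the four groups shown that stands apart. No measurement is available that explains this difference between the groups.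

Still open, as far as these compounds go, is whether the lower number belongs to pyridin-2-yl alone or extends to pyridin-3-yl or pyridin-4-yl. From the compounds shown here alone, it is also open whether thiophen-2-yl without the bromine would group with compound 4 or with compound 3.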